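A few compounds are considered here, and "the series" means these few. Any claim that something is new, unique, unknown or untested is made for them only; others in the source may bear on it.

Going by the values given here, compound 1 `CNC(=O)c1cc(C(=O)N[C@H]2CC[C@H](O)CC2)n([C@@H](C)c2ccccc2)n1` gives 80 nm/s in an ADME assay for permeability; a higher number here means that the compound crosses the layer faster, a lower number that the compound crosses the layer more slowly; only one other number is in hand, that of compound 2 `CNC(=O)c1cc(C(=O)N[C@H]2CC[C@H](O)CC2)n([C@@H](C)c2cccc(C)c2)n1`, which gives 110 nm/s, and the step of a 1.4-fold higher number from compound 1 to compound 2 (0.14 log units; within the scatter) is within the scatter. Compound 3 `CNC(=O)c1cc(C(=O)NC(C)CO)n([C@@H](C)c2ccccc2)n1` is not yet measured in this assay; it differs from compound 1 by 1-(hydroxymethyl)ethyl in place of 4-hydroxycyclohexyl on an amide-type nitrogen. Among the compounds with values here, the single measured step concerns a methyl on an aromatic carbon and does not bear on a change at the amide-type nitrogen, so nothing grounds a direction. The expected step is therefore no change at the digits printed from compound 1 to compound 3 (within the scatter), none beyond the scatter. Compound 3 is estimated at 80 nm/s, with a range from 40 nm/s to 160 nm/s.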

Compound 3, apparent permeability: 120 nm/s
For compound 3 the middle estimate is 1.5-fold (0.18 log units) below the measured one, and the stated range covers the measured number.
By their numbers in this assay, from the lowest: compounds 1, 2 and 3 (each within the scatter of the next).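

Replacing the ring at the amide-type nitrogen with an open chain gives a 1.5-fold higher number from compound 1 to compound 3 (0.18 log units; within the scatter) in this assay, so this measurement does not separate 1-(hydroxymethyl)ethyl from 4-hydroxycyclohexyl. Here the six-membered ring goes and the hydrogen-bond donor and acceptor counts stay the same, and the read-out at this position still stays within the scatter. No supporting evidence bears on this result.

The compounds shown leave open whether an amine or a carboxylic acid at this nitrogen would give a step beyond the scatter. They also leave open how a longer chain would read.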